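The source may report more compounds than this note shows. Statements on the series, on what has been measured and on what is new or still open speak of the compounds shown alone.

Measured compounds in a functional assay on L1210 cells (Mus musculus) for antiproliferative activity; a lower number here means that less compound is needed, a higher number that more compound is needed for the effect:
compound 1 `CCCCCCCCCCCCO/N=C(\CCCCCC)c1cc(OC)c2c(c1OC)C(=O)C=CC2=O`: 0.193 ug/mL
compound 2 `CCCCCC/C(=N\OCCC)c1cc(OC)c2c(c1OC)C(=O)C=CC2=O`: 0.166 ug/mL

Compound 2 has the lowest of the two numbers in this assay, but the step of a 1.2-fold lower number from compound 1 to compound 2 (0.07 log units; within the scatter) lies within the scatter, so no order between the two is shown.

Compound 3 `CCCCCCCO/N=C(\CCCCCC)c1cc(OC)c2c(c1OC)C(=O)C=CC2=O` differs from compound 2 by butyl in place of hydrogen on a saturated chain carbon, three bonds along the chain from an oxygen on an unsaturated carbon. Going by the values given here, the only comparable step is a 1.2-fold lower number from compound 1 to compound 2 (0.07 log units; within the scatter), which was within the scatter; the chain of compound 3 lies between those of compound 1 and compound 2. No change beyond the scatter is therefore expected. The expected step is a 1.1-fold higher number from compound 2 to compound 3 (0.04 log units; within the scatter). Compound 3 is estimated at 0.18 ug/mL, range 0.1 ug/mL to 0.33 ug/mL.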

Compound 3, concentration for half-maximal effect: 0.162 ug/mL
Beside the measured number, compound 3's estimate is 1.1-fold (0.05 log units) above it, and the stated range covers the measured number.
By their numbers in this assay, from the lowest: compounds 3, 2 and 1 (each within the scatter of the next).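

In this assay, butyl in place of hydrogen at this position, three bonds along the chain from an oxygen on an unsaturated carbon, gives a 1.0-fold lower number from compound 2 to compound 3 (0.01 log units; within the scatter) and the further step gives a 1.2-fold lower number from compound 1 to compound 3 (0.08 log units; within the scatter), both within the scatter. With a third chain length in hand, the three compounds show no difference beyond the scatter across this range of saturated chains. No available evidence bears on this result.

Going by these compounds, whether a chain ending in an amine or a carboxylic acid would keep these values remains open. So does the effect of replacing the hexyl chain, which all three compounds share.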